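Working notes: from compound 3 to compound 4

A few compounds are considered here, and "the series" means these few. Any claim that something is new, unique, unknown or untested is made for them only; others in the source may bear on it.

Measured in an ADME assay on MT4 cells (Homo sapiens) for cytotoxicity, read by MTT assay, with a stated time of 5 days; on this read-out higher numbers stand for lower toxicity in this test and lower numbers for higher toxicity in this test:
- compound 1 `N#Cc1ccc(Nc2nccc(OCC(=O)Nc3ccc(C#N)cc3F)n2)cc1`: > 321000 nM (a limit)
- compound 2 `Cc1cnc(Nc2ccc(C#N)cc2)nc1OCC(=O)Nc1ccccc1F`: > 331000 nM (a limit)
- compound 3 `Cc1cnc(Nc2ccc(C#N)cc2)nc1OCC(=O)Nc1ccccc1Cl`: 197000 nM

Compound 3 is the only one of the three with a number rather than a limit in this assay.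

The next compound is compound 4 `Cc1cnc(Nc2ccc(C#N)cc2)nc1OCC(=O)Nc1ccc(C#N)cc1F`, which differs from compound 3 as follows: 4-cyano-2-fluorophenyl in place of 2-chlorophenyl on an amide-type nitrogen. In words, this is 4-cyano-2-fluorophenyl in place of 2-chlorophenyl on an amide-type nitrogen.

Going by the values given here, one measured step bears on this directly: an at least 1.6-fold lower number from compound 2 to compound 3 (0.22 log units; that floor lies within the scatter), with chloro in place of fluoro on an aromatic carbon. The floor of that step lies within the scatter, so it gives only weak guidance. Compound 1 carries the same 4-cyano-2-fluorophenyl group, and its result is a limit, > 321000 nM.

A small rise, not clearly beyond the scatter, is therefore expected, and the expected step is a 1.3-fold higher number from compound 3 to compound 4 (0.10 log units; within the scatter). For compound 4 the estimated value is 250000 nM, with an expected range of 90000 nM to 330000 nM.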

Compound 4, half-maximal cytotoxic concentration: > 310000 nM
Compound 4 ended at the assay's limit (the forecaster's own chance of this, stated with the estimate: 55%); middle value at least 1.2-fold (0.09 log units) away from the limit.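

In this assay, compound 4 gives > 310000 nM, which is a limit and not a number. Going by these compounds alone, the change to 4-cyano-2-fluorophenyl on the amide-type nitrogen gives an at least 1.5-fold higher number from compound 3 to compound 4 (0.19 log units; that floor lies within the scatter), so this step does not separate the two compounds beyond the scatter, and compound 3 remains the only one with a number. The steps to compound 4 from compound 1 and from compound 2 cannot be read, with a limit at each end: the limit of > 310000 nM in this assay, at which 1 of the 4 values shown sits.

As far as these compounds go, the values behind the three limits remain unknown, so the size of any effect of the cyano group or the methyl group on this read-out stays open. Also open, from the compounds shown here alone, is how a carboxylic acid or an amine in place of the cyano group would read in this assay.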